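Swapping the ring on the sulfonyl group: compound 1 to compound 4

The source may hold more compounds than are shown below. What is called first, only, known or untested is meant among the compounds shown, and "the series" means these compounds.

Compound 1 `O=C(Nc1ccc(F)c(Cl)c1)c1ccc(F)c(S(=O)(=O)N2CCOC[C@H](O)C2)c1` was tested in an ADME assay on HepG2 2.2.15 cells (Homo sapiens) for cytotoxicity, read by luminescence, with a stated time of 3 days (a lower number here means that less compound is tolerated, a higher number that more compound is tolerated), where compound 1 gives 19000 nM. Among the three measured compounds it holds the second highest number: compound 2 `O=C(Nc1ccc(F)c(Cl)c1)c1ccc(F)c(S(=O)(=O)N2CCCCC(O)CC2)c1` gives 24000 nM, and compound 3 `CC1(O)CCCN(S(=O)(=O)c2cc(C(=O)Nc3ccc(F)c(Cl)c3)ccc2F)CC1` gives 11000 nM. Among the measured compounds shown here, the step of a 1.3-fold higher number from compound 1 to compound 2 (0.10 log units; within the scatter) and the step of a 1.7-fold lower number from compound 1 to compound 3 (0.24 log units; within the scatter) both stay within the scatter; only the step of a 2.2-fold lower number from compound 2 to compound 3 (0.34 log units; beyond the scatter) reaches beyond it, and modestly.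

Compound 4 `O=C(Nc1ccc(F)c(Cl)c1)c1ccc(F)c(S(=O)(=O)N2CCCCC(O)C2)c1` has not been measured. It differs from compound 1 in one place: 3-hydroxyazepan-1-yl in place of 6-hydroxy-1,4-oxazepan-4-yl on a sulfonyl sulfur. The seven-membered ring keeps its hydroxy group but carries one hetero atom instead of two. The two earlier ring changes from compound 1 moved the number little, so in this assay the step of a 1.2-fold lower number from compound 1 to compound 4 (0.07 log units; within the scatter) is expected to stay within the scatter. The estimate for compound 4 is 16000 nM, with a range from 8000 nM to 32000 nM.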

Compound 4, half-maximal cytotoxic concentration: 15000 nM
Compound 4: the middle estimate sits 1.1-fold (0.03 log units) above what was measured; low and high end bracket the measured number.
By their numbers in this assay, from the lowest: compounds 3, 4, 1 and 2 (each within the scatter of the next, the first and the last beyond it).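

In this assay, the step of a 1.3-fold lower number from compound 1 to compound 4 (0.10 log units; within the scatter) shows that a seven-membered ring on the sulfonyl sulfur can carry one hetero atom instead of two without a readable change in the number. The steps of a 1.4-fold higher number from compound 3 to compound 4 (0.13 log units; within the scatter) and a 1.6-fold lower number from compound 2 to compound 4 (0.20 log units; within the scatter) place compound 4 within the scatter of every earlier compound, so it does not sharpen the gap between the two most separated rings. No measured evidence accounts for these small steps.

Still open, from the compounds shown here alone, is what happens when an amine or a carboxylic acid replaces the hydroxy group on the ring.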